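A few compounds are considered here, and "the series" means these few. Any claim that something is new, unique, unknown or untested is made for them only; others in the source may bear on it.

In a toxicity assay on THP-1 cells (Homo sapiens) for inhibition (a lower number here means that less compound is tolerated, a higher number that more compound is tolerated), three compounds have been tested, and none gave a number. Compound 1 `Cn1c(-c2ccccc2Cl)cnc1NC(=O)c1ncc[nH]1` reached only a limit of the assay, > 50000 nM. Compound 2 `Cn1c(-c2ccccc2Cl)cnc1NC(=O)c1ccc(F)cc1` likewise stopped at a limit, > 50000 nM. Compound 3 `COc1cccc(-c2cnc(NC(=O)c3ccc(F)cc3)n2C)c1` stopped at a limit as well, > 100000 nM. Because every value sits at the limit of > 100000 nM in this assay, at which 1 of the 3 values shown sits, or (the limit of > 50000 nM in this assay, at which 2 of the 3 values shown sit), the measured steps cannot be read: the change 1H-imidazol-2-yl in place of 4-fluorophenyl on a carbonyl carbon gives a step that the two limits leave unreadable from compound 2 to compound 1, and the change in the core, (3-methoxyphenyl in place of 2-chlorophenyl on an aromatic carbon), gives a step that the two limits leave unreadable from compound 2 to compound 3.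

Compound 4 `COc1cccc(-c2cnc(NC(=O)c3ncc[nH]3)n2C)c1` has not yet been measured in this assay. It differs from compound 3 by 1H-imidazol-2-yl in place of 4-fluorophenyl on a carbonyl carbon, the same change that leads from compound 2 to compound 1, on the same kind of carbonyl carbon with an amide-type nitrogen as other neighbour. Since all three measured compounds tolerated the highest concentration applied, the step from compound 3 to compound 4 is expected to be a number no higher from compound 3 to compound 4 (the limit leaves the size open). Compound 4 is therefore estimated to give 100000 nM, most likely again as a limit rather than a number, between 50000 nM and 200000 nM.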

Compound 4, half-maximal cytotoxic concentration: > 100000 nM
Compound 4: no number, only a limit; the forecaster's own chance of this, stated with the estimate: 85%; the middle value sits exactly at the limit.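

In this assay compound 4 gives > 100000 nM, which is a limit of the assay and not a number. No step from compound 3 to compound 4 can be read, because both compounds stop at the same limit: the limit of > 100000 nM in this assay, at which 2 of the 4 values shown sit.

The compounds shown leave open at what concentration any of them would become toxic to these cells, and whether 1H-imidazol-2-yl in place of 4-fluorophenyl changes that concentration at all.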